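Chlorinated Carboxyphenyl Variant in a Glutamate Receptor Modulator Series

A few compounds are considered here, and "the series" means these few. Any claim that something is new, unique, unknown or untested is made for them only; others in the source may bear on it.

Measured compounds:
compound 1, `COC(=O)c1ccc(OCCCCOc2ccc(C(=O)CC3CCCC3)c(O)c2C)cc1`: "not determined" (no result reported)
compound 2, `Cc1c(OCCCCOc2cccc(C(=O)O)c2)ccc(C(=O)CC2CCCC2)c1O`: 3400 nM

The study examines a pair of ether-linked phenyl ketones. Compound 1 carries a methyl ester on its outer ring, but in an assay on HEK293 cells for positive allosteric modulation of metabotropic glutamate receptor 3 (Rattus norvegicus), read by thallium flux, with a stated time of 2.5 min (a lower number here means that less compound is needed, a higher number that more compound is needed for the effect), compound 1 gives "not determined" (no result reported). In this assay, among the measured compounds shown here, compound 2 gives 3400 nM, and since compound 1 has no result, compound 2 stands as the only compound in this set with a measured number, so no comparison within the measured compounds is possible.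

The unmeasured compound 3, `Cc1c(OCCCCOc2ccc(C(=O)O)c(Cl)c2)ccc(C(=O)CC2CCCC2)c1O`, differs from compound 2 in one place: 4-carboxy-3-chlorophenyl in place of 3-carboxyphenyl on an oxygen on a saturated carbon. For the measured compounds named here, no measured pair in this set shows a comparable step, so there is no step to lean on. The change keeps the carboxylic acid and adds a chlorine on the outer ring. Without any measured analogue of this kind of change, the expected step is small, in no particular direction, and unlikely to exceed the scatter of repeated measurements. The expected step from compound 2 to compound 3 is thus a 1.1-fold lower number from compound 2 to compound 3 (0.05 log units; within the scatter). Compound 3 is estimated at 3000 nM in this assay, with a range from 900 nM to 10000 nM.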

Compound 3, half-maximal effective concentration: 2250 nM
The estimate for compound 3 lay 1.3-fold (0.12 log units) above the measured number; low and high end bracket the measured number.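

In this assay, among the compounds shown here, the exchange of 3-carboxyphenyl for 4-carboxy-3-chlorophenyl on an oxygen on a saturated carbon gives a 1.5-fold lower number from compound 2 to compound 3 (0.18 log units; within the scatter) and this is the first step in the set that can be read at this place. The new outer ring keeps the carboxylic acid, places it differently and adds a chlorine, and these changes taken together leave the number within the scatter of repeated measurements. The step itself cannot separate the share of the chlorine from that of the carboxylic acid's new place, and nothing at hand offers an explanation for the result.

As far as these compounds go, it remains open whether the chlorine alone, on the 3-carboxyphenyl ring, would give the same reading, and whether a bromine, a methyl group or a methoxy group could stand in the chlorine's place with a similar result. Also open, from the compounds shown here alone, is whether a tetrazole in place of the carboxylic acid, or a longer chain leading to the outer ring, would move the number beyond the scatter.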